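Cytotoxicity of Dibenzylidene Piperidinones Toward L02 Cells

This account rests on a few compounds, and the source may have more. Where it says the series, first, only, none or still open, it means among the compounds named here.

Measured so far:
compound 1, `COc1cc(/C=C2\CN(C)C/C(=C\c3ccc(Cl)c(Cl)c3)C2=O)cc(OC)c1`: 10600 nM
compound 2, `COc1cc(/C=C2\CN(C)C/C(=C\c3cccc([N+](=O)[O-])c3)C2=O)cc(OC)c1`: 10800 nM
compound 3, `COc1cc(/C=C2\CN(C)C/C(=C\c3ccc(Cl)c(Cl)c3)C2=O)cc(OC)c1OC`: 18400 nM

The three compounds were tested in an ADME assay on L02 cells (Homo sapiens) for cytotoxicity, read by MTT assay, with a stated time of 24 h; on this read-out higher numbers stand for weaker inhibition and lower numbers for stronger inhibition. Compound 4, `COc1cc(/C=C2\CN(C)C/C(=C\c3cccc([N+](=O)[O-])c3)C2=O)cc(OC)c1OC`, has not yet been measured in this assay. It is related to compound 3 by the same change that relates compound 1 to compound 2: 3-nitrophenyl in place of 3,4-dichlorophenyl on a double-bonded chain carbon bound to a double-bonded ring carbon. That change gave a 1.0-fold higher number from compound 1 to compound 2 (0.01 log units; within the scatter), so the two compounds cannot be told apart on this read-out. Compound 3 differs from compound 1 in its core by methoxy in place of hydrogen on an aromatic carbon, and that difference gave a 1.7-fold higher number from compound 1 to compound 3 (0.24 log units; within the scatter). Compound 4 differs from compound 3 by 3-nitrophenyl in place of 3,4-dichlorophenyl on a double-bonded chain carbon bound to a double-bonded ring carbon, with the place described in the same words as for the step from compound 1 to compound 2, so it is the same change made on the core of compound 3.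

Because the earlier instance of this change gave a 1.0-fold higher number from compound 1 to compound 2 (0.01 log units; within the scatter), the step from compound 3 to compound 4 is expected to be a 1.0-fold higher number from compound 3 to compound 4 (0.00 log units; within the scatter). Compound 4 is therefore estimated at 18500 nM in this assay, with a likely range from 9000 nM to 37000 nM.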

Compound 4, half-maximal inhibitory concentration: 13600 nM
Compound 4: the middle estimate sits 1.4-fold (0.13 log units) above what was measured, and the stated range covers the measured number.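

In this assay, putting 3-nitrophenyl in place of 3,4-dichlorophenyl gave a 1.4-fold lower number from compound 3 to compound 4 (0.13 log units; within the scatter) and so behaved on the methoxy-bearing core of compound 3 as it had on the core of compound 1: the same change on two cores in this assay, a 1.0-fold higher number (0.01 log units; within the scatter) from compound 1 to compound 2 and a 1.4-fold lower number (0.13 log units; within the scatter) from compound 3 to compound 4, 1.4-fold (0.14 log units) apart, within the scatter of two such steps.

The added methoxy gave a 1.3-fold higher number from compound 2 to compound 4 (0.10 log units; within the scatter) and likewise agreed with its earlier instance: the same change on two cores in this assay, a 1.7-fold higher number (0.24 log units; within the scatter) from compound 1 to compound 3 and a 1.3-fold higher number (0.10 log units; within the scatter) from compound 2 to compound 4, 1.4-fold (0.14 log units) apart, within the scatter of two such steps.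

For the compounds shown here, both changes therefore carried from one core to the other without a difference that can be told from the scatter, but every step here also lies within the scatter, so the four compounds show only that these changes stay small on these two cores, not that a change with a clear effect would carry over in the same way.

The compounds shown leave open whether a phenyl bearing an amine or a carboxylic acid in place of 3-nitrophenyl would stay as close to these numbers. They also leave open whether an ethoxy or a longer alkoxy chain in place of the added methoxy would do the same.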